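The source may hold more compounds than are shown below. What is called first, only, known or untested is meant among the compounds shown, and "the series" means these compounds.

Two pairs of compounds in this set share one small structural change, and both are followed in a functional assay on HCT-8 cells (Homo sapiens) for antiproliferative activity, read by MTT assay, with a stated time of 48 h; a lower number here means a stronger inhibitor, a higher number a weaker inhibitor. Compound 1 `CNCC(=O)Nc1cc(OC)ccc1C(=O)c1cc(OC)c(OC)c(OC)c1` gives 780 nM in this assay. Compound 2 `CCNCC(=O)Nc1cc(OC)ccc1C(=O)c1cc(OC)c(OC)c(OC)c1` carries methyl in place of hydrogen on a saturated chain carbon bound to an amine nitrogen and gives 1560 nM in this assay. The resulting step is a 2.0-fold higher number from compound 1 to compound 2 (0.30 log units; within the scatter), which leaves the two values where repeated measurements would not tell them apart.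

Compound 3 `C=C(c1ccc(OC)cc1NC(=O)CNC)c1ccc(OC)c2c1C=CC(C)(C)O2` is built on a different core; the difference between its core and the core of compound 1 is not broken down here. In this assay compound 3 gives 980 nM, a value that sits close to those of compound 1 and compound 2.

Compound 4 `C=C(c1ccc(OC)cc1NC(=O)CNCC)c1ccc(OC)c2c1C=CC(C)(C)O2` has not yet been measured in this assay. It differs from compound 3 by methyl in place of hydrogen on a saturated chain carbon bound to an amine nitrogen. The place of the change reads the same as in the first pair, so the change made here is the same one carried over onto the other core. Because the step of a 2.0-fold higher number from compound 1 to compound 2 (0.30 log units; within the scatter) stayed within the scatter, the expected step for the new pair is of similar size, and the estimate means a step of a 1.7-fold higher number from compound 3 to compound 4 (0.24 log units; within the scatter). Among the measured compounds shown here, that expectation rests on a single earlier example, as no other pair in the set shows this change. For compound 4 the expected value in this assay is 1700 nM, with a likely range from 800 nM to 3600 nM.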

Compound 4, half-maximal inhibitory concentration: 3050 nM
Compound 4: the middle estimate sits 1.8-fold (0.25 log units) below what was measured; low and high end bracket the measured number.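

In this assay, the change from methylamino to ethylamino on the core of compound 3 gives a 3.1-fold higher number from compound 3 to compound 4 (0.49 log units; beyond the scatter), and set beside the same change on the core of compound 1, the two steps cannot be told apart: the same change on two cores in this assay, a 2.0-fold higher number (0.30 log units; within the scatter) from compound 1 to compound 2 and a 3.1-fold higher number (0.49 log units; beyond the scatter) from compound 3 to compound 4, 1.6-fold (0.19 log units) apart, within the scatter of two such steps. Among the compounds shown here, this shows that the change carried from one core to the other without any measurable difference in the size of its step, even though only the step on the second core stands clear of the scatter on its own. For the compounds shown here, it does not show that the change costs more on the second core, it gives no reason for either step, and with only two pairs on two cores it sets no rule for any further core.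

The compounds shown leave open how the series would respond as the group on the amine grows beyond ethyl, for instance to a longer chain such as propyl, a branched group such as isopropyl, or a cyclic amine such as pyrrolidine. They also leave open whether any such group would follow the same course on both cores in this assay.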